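This account rests on a few compounds, and the source may have more. Where it says the series, first, only, none or still open, it means among the compounds named here.

Of the compounds shown here, two have been measured in a functional assay on PC-3 cells (Homo sapiens) for cytotoxicity, read by MTT assay, with a stated time of 72 h; on this read-out lower numbers stand for stronger inhibition and higher numbers for weaker inhibition. Compound 1 `[O-][n+]1nc(NCOCc2ccccc2)[n+]([O-])c2ccccc21` gives 13400 nM, and compound 2 `CCCCCOCNc1n[n+]([O-])c2cc(OC)ccc2[n+]1[O-]` gives 3630 nM. Of the two, compound 2 stands at the lower number, that is the stronger inhibition, and its gap to compound 1 lies beyond the usual scatter of repeated measurements.

Compound 3 `COc1ccc2c(c1)[n+]([O-])nc(NCOCc1ccccc1)[n+]2[O-]` has not yet been measured. It follows from compound 2 by a single change, (phenyl in place of butyl on a saturated chain carbon bound to an oxygen on a saturated carbon). The amine-bearing core and its methoxy group stay as they are in compound 2; only the tail beyond the oxygen on the saturated carbon is exchanged, a straight chain for an aromatic ring.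

Within the data shown here, no measured pair in this set isolates exactly this exchange, so the size of the step cannot be read off directly. In this assay the step from compound 2 to compound 3 is expected to move the number somewhat upward, toward weaker inhibition, by about a 1.9-fold higher number from compound 2 to compound 3 (0.29 log units; within the scatter), though a result within the scatter would not be surprising. The value of compound 3 is therefore estimated at 7000 nM, with a plausible range from 2500 nM to 20000 nM.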

Compound 3, half-maximal inhibitory concentration: 8580 nM
Estimate against measurement, compound 3: 1.2-fold (0.09 log units) below; low and high end bracket the measured number.
By their numbers in this assay, from the lowest: compound 2; then compounds 3 and 1 (each within the scatter of the next).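

In this assay the tail beyond the oxygen proves to matter: with the core and its methoxy group held fixed, phenyl in place of butyl on a saturated chain carbon bound to an oxygen on a saturated carbon gives a 2.4-fold higher number from compound 2 to compound 3 (0.37 log units; beyond the scatter) and so a modest loss of inhibition. Among these compounds, the same compound also allows the first reading of the methoxy group on its own, since methoxy in place of hydrogen on an aromatic carbon gives a 1.6-fold lower number from compound 1 to compound 3 (0.19 log units; within the scatter) and, with the benzyloxy tail in place, that step cannot be told apart from the ordinary spread of repeated measurements. No independent measurement offers an explanation for either step.

Whether the methoxy group would make a larger difference with the pentyloxy tail stays open, as the compounds shown include no partner of compound 2 without that group. Also open, as far as these compounds go, is how a longer chain such as octyl, or a cyclohexyl ring, would compare with the butyl and phenyl groups at this place in this assay on these cells.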